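A Chloro for Fluoro Swap at the Assay Limit

The compounds below may be only part of what the source reports. "The series", "measured", "known", "first", "only" and "open" are said of these compounds alone.

Compounds measured so far in an ADME assay on MCF7 cells (Homo sapiens) for cytotoxicity, read by MTT assay, with a stated time of 48 h; on this read-out higher numbers stand for weaker inhibition and lower numbers for stronger inhibition
Compound 1 `Clc1ccc(-c2[nH]c3cc(Cl)ccc3c2Cn2ccnc2)cc1` gives > 1000000 nM
Compound 2 `COc1ccc2c(Cn3ccnc3)c(-c3ccc(F)cc3)[nH]c2c1` gives > 1000000 nM

Compound 2 stands at > 1000000 nM as a limit of the assay, not a number. For the measured compounds named here, the data hold only the limit of > 1000000 nM in this assay, at which 2 of the 2 values shown sit, and no step between measured compounds. Compound 3 `COc1ccc2c(Cn3ccnc3)c(-c3ccc(Cl)cc3)[nH]c2c1` differs from compound 2 by chloro in place of fluoro on an aromatic carbon with chloro in place of fluoro on an aromatic carbon, para to a large group. Compound 1, which also carries 4-chlorophenyl, reads > 1000000 nM as a limit too. The expected step of a number no higher from compound 2 to compound 3 (the limit leaves the size open) in this assay is none beyond the scatter, and another limit is likely. The estimate for compound 3 is 1000000 nM (expected range 300000 nM to 2000000 nM).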

Compound 3, half-maximal inhibitory concentration: > 1000000 nM
Compound 3 ended at the assay's limit (the forecaster's own chance of this, stated with the estimate: 80%); the middle value sits exactly at the limit.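

In this assay compound 3 gives > 1000000 nM, a limit of the assay and not a number. No step from compound 1 or compound 2 to compound 3 can be read: the limit of > 1000000 nM in this assay, at which 3 of the 3 values shown sit.

The compounds shown leave open whether 4-fluorophenyl and 4-chlorophenyl differ at all in this read-out.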